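From compound 3 to compound 4: an exchange of amine group

The compounds below may be only part of what the source reports. "The series", "measured", "known", "first", "only" and "open" are said of these compounds alone.

compound 1 `CCNC(=O)c1nnn(-c2cc(C(C)C)c(O)cc2O)c1-c1ccc(CN2CCNCC2)cc1` gives 250 nM
compound 2 `CCNC(=O)c1nnn(-c2cc(C(C)C)c(O)cc2O)c1-c1ccc(CN2CCN(C)CC2)cc1` gives 47 nM
compound 3 `CCNC(=O)c1nnn(-c2cc(C(C)C)c(O)cc2O)c1-c1ccc(CN2CCC(N(C)C)CC2)cc1` gives 120 nM

In a functional assay on NCI-H460 cells (Homo sapiens) for inhibition, read by sulforhodamine B assay, with a stated time of 72 h (on this read-out lower numbers stand for stronger inhibition and higher numbers for weaker inhibition), compound 3 holds the middle place of the three values, lower than compound 1 and higher than compound 2. Compound 4 `CCNC(=O)c1nnn(-c2cc(C(C)C)c(O)cc2O)c1-c1ccc(CNCC2CCCCC2)cc1` has (cyclohexylmethyl)amino in place of 4-(dimethylamino)piperidin-1-yl on a saturated chain carbon bound to an aromatic carbon. The measured exchanges at this place were all modest: a 2.1-fold lower number from compound 1 to compound 3 (0.32 log units; beyond the scatter), a 2.6-fold higher number from compound 2 to compound 3 (0.41 log units; beyond the scatter) and a 5.3-fold lower number from compound 1 to compound 2 (0.73 log units; beyond the scatter). None of them introduces the entering group, so the data fix no direction, and in this assay a step of similar size at most is expected. The estimate means a 1.3-fold higher number from compound 3 to compound 4 (0.10 log units; within the scatter), so no clear change is expected. For compound 4 the estimated value is 150 nM, with an expected range from 50 nM to 450 nM.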

Compound 4, half-maximal inhibitory concentration: 2.1 nM
Compound 4: middle estimate off by 71-fold (1.85 log units), on the high side; the measured number lies below the stated range.
By their numbers in this assay, from the lowest: compound 4; then compound 2; then compound 3; then compound 1.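

In this assay, the amine group on this saturated chain carbon bound to an aromatic carbon can move the number much further than the earlier modest exchanges showed: a 57-fold lower number from compound 3 to compound 4 (1.76 log units; beyond the scatter), a 22-fold lower number from compound 2 to compound 4 (1.35 log units; beyond the scatter) and a 120-fold lower number from compound 1 to compound 4 (2.08 log units; beyond the scatter). The entering (cyclohexylmethyl)amino has a six-membered ring of carbon only and a hydrogen-bond donor, unlike 4-(dimethylamino)piperidin-1-yl and 4-methylpiperazin-1-yl. No evidence is available that bears on this large gain.

The compounds shown do not separate the effect of the carbon-only ring from that of the amine hydrogen. A piperidin-1-yl or a (cyclohexylmethyl)(methyl)amino group at this place would bear on that question.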